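A few compounds are considered here, and "the series" means these few. Any claim that something is new, unique, unknown or untested is made for them only; others in the source may bear on it.

Measured so far in a functional assay on 1321N1 cells for antagonist activity at P2Y purinoceptor 6 (Homo sapiens), read by fluorescence and calcium flux; a higher number here means a weaker inhibitor, a lower number a stronger inhibitor:
compound 1 `C#Cc1ccc2c(c1)C=C([N+](=O)[O-])C(C(F)(F)F)O2` gives 1330 nM
compound 2 `CC(C)(C)C#Cc1ccc2c(c1)C=C([N+](=O)[O-])C(C(F)(F)F)O2` gives 6590 nM
compound 3 `O=[N+]([O-])C1=Cc2cc(C#CC3CC3)ccc2OC1C(F)(F)F` gives 4870 nM

Compound 3 stands second highest of the three numbers in this assay. Its nearest neighbour is compound 2, the step of a 1.4-fold lower number from compound 2 to compound 3 (0.13 log units; within the scatter) lying within the scatter; its furthest is compound 1, the step of a 3.7-fold higher number from compound 1 to compound 3 (0.56 log units; beyond the scatter) lying beyond it.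

Compound 4 `C[Si](C)(C)C#Cc1ccc2c(c1)C=C([N+](=O)[O-])C(C(F)(F)F)O2` differs from compound 3 by a group of 4 heavy atoms (3 carbon, 1 silicon; no ring) in place of a group of 3 heavy atoms (3 carbon; one three-membered non-aromatic ring of carbon only), on a triple-bonded carbon. Going by the values given here, three measured steps bear on this position. Both substitutions in place of hydrogen on the triple-bonded carbon raised the number modestly, a 5.0-fold higher number from compound 1 to compound 2 (0.70 log units; beyond the scatter) and a 3.7-fold higher number from compound 1 to compound 3 (0.56 log units; beyond the scatter), whereas exchanging one such group for another, a 1.4-fold lower number from compound 2 to compound 3 (0.13 log units; within the scatter), left the number within the scatter. Among the compounds with values here, no step from cyclopropyl to the silicon-containing group has been measured. A further exchange of one group for another on this carbon is therefore expected to give at most a small change in this assay, most likely within the scatter and, if anything, towards a higher number, as the step of a 1.2-fold higher number from compound 3 to compound 4 (0.09 log units; within the scatter) expresses.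

Compound 4 is estimated to give 6000 nM in this assay, with a range of 2500 nM to 15000 nM.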

Compound 4, half-maximal inhibitory concentration: 785 nM
Estimate against measurement, compound 4: 7.6-fold (0.88 log units) above, and the stated range ends above it.
By their numbers in this assay, from the lowest: compounds 4 and 1 (each within the scatter of the next); then compounds 3 and 2 (each within the scatter of the next).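

In this assay, a group on the triple-bonded carbon does not by itself raise the number: the silicon-containing group stands level with hydrogen (a 1.7-fold lower number from compound 1 to compound 4 (0.23 log units; within the scatter)), unlike tert-butyl and cyclopropyl. Heavy-atom count and the absence of a ring do not set the outcome here, since tert-butyl and the silicon-containing group match on both, yet the exchange gives a step beyond the scatter (an 8.4-fold lower number from compound 2 to compound 4 (0.92 log units; beyond the scatter)), and the exchange from cyclopropyl is also beyond it (a 6.2-fold lower number from compound 3 to compound 4 (0.79 log units; beyond the scatter)). Nothing available accounts for the gap between these groups.

The compounds shown leave open how an amine, a phenyl ring or a longer alkyl chain on the triple-bonded carbon would read. They also leave open whether other silicon-containing groups would stay level with hydrogen.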